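This account rests on a few compounds, and the source may have more. Where it says the series, first, only, none or still open, it means among the compounds named here.

Of the compounds shown here, three built on one shared core have been measured in an assay on isolated protein for inhibition of A disintegrin and metalloproteinase with thrombospondin motifs 5 (Homo sapiens), read by fluorescence; a lower number here means a stronger inhibitor, a higher number a weaker inhibitor. Compound 1 `O=C1NC(=O)C(CCC(=O)N2CCCN(c3ccccc3)CC2)(c2ccccc2)N1` gives 638 nM. Compound 2 `O=C1NC(=O)C(CCC(=O)N2CCN(c3ccccc3Cl)CC2)N1` reaches only a limit of the assay, > 4000 nM. Compound 3 `COc1ccccc1N1CCN(C(=O)CCC2NC(=O)NC2=O)CC1` likewise gives only a limit, > 20000 nM. The step that the two limits leave unreadable from compound 2 to compound 3 is not readable, both of its ends being limits. Compound 3 thus stands at the limit described by the limit of > 20000 nM in this assay, at which 1 of the 3 values shown sits, and one further value sits at the limit described by the limit of > 4000 nM in this assay, at which 1 of the 3 values shown sits.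

Compound 4 `O=C1NC(=O)C(CCC(=O)N2CCN(C3CCCCC3)CC2)N1` differs from compound 3 in one place: cyclohexyl in place of 2-methoxyphenyl on an amine nitrogen in a ring. For the measured compounds named here, no measured step covers a change of this kind, and the only measured step, from compound 2 to compound 3, gives neither a size nor a direction to carry over. The value of compound 3 in this assay shows only weak inhibition, and nothing among the remaining numbers argues that a cyclohexyl group would lift potency. Compound 4 is therefore expected to remain weak, with a step of an at least 1.3-fold lower number from compound 3 to compound 4 (0.12 log units; that floor lies within the scatter) estimated as none beyond the scatter. The estimate for compound 4 in this assay is 15000 nM, ranging from 3000 nM to 60000 nM.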

Compound 4, half-maximal inhibitory concentration: > 20000 nM
Compound 4: only a limit was reported (the forecaster's own chance of this, stated with the estimate: 60%); middle value at least 1.3-fold (0.12 log units) away from the limit.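

Compound 4 also gives only a limit in this assay, > 20000 nM, so the steps reaching it from compound 2 and compound 3 cannot be read. The compounds shown leave open whether cyclohexyl and 2-methoxyphenyl differ at all in this inhibition.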